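The source may report more compounds than this note shows. Statements on the series, on what has been measured and on what is new or still open speak of the compounds shown alone.

Of the compounds shown here, three have been measured in a functional assay on COLO 205 cells (Homo sapiens) for inhibition, read by sulforhodamine B assay, with a stated time of 48 h; a lower number here means a stronger inhibitor of growth, a higher number a weaker inhibitor of growth. Compound 1 `O=CN1CCN(c2ccc(Cl)cc2)C1=S` gives 20700 nM, the highest number of the three. Compound 2 `COc1cc(C(=O)N2CCN(C=O)C2=S)cc(OC)c1OC` gives 20200 nM, which lies within the usual scatter of the value of compound 1, so the two cannot be told apart. Compound 3 `O=CN1CCN(C(=O)c2ccco2)C1=S` gives 8700 nM, a lower number than compound 1 by more than the scatter. Compound 4 `O=CN1CCN(c2ccc(Cl)c(Cl)c2)C1=S` has not yet been measured in this assay. It differs from compound 1 in one place: chloro in place of hydrogen on an aromatic carbon. Among the measured compounds shown here, no measured pair shows what such a change does here, so the expectation rests on compound 1 alone. The step expected is a 1.6-fold lower number from compound 1 to compound 4 (0.20 log units; within the scatter), small and toward a lower number, probably not beyond the scatter. Compound 4 is estimated at 13000 nM, in a range from 4000 nM to 40000 nM.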

Compound 4, concentration for 50% growth inhibition: 20000 nM
Beside the measured number, compound 4's estimate is 1.5-fold (0.19 log units) below it; low and high end bracket the measured number.
By their numbers in this assay, from the lowest: compound 3; then compounds 4, 2 and 1 (each within the scatter of the next).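

Putting chloro in place of hydrogen on this aromatic carbon, ortho to a chloro group, gives a 1.0-fold lower number from compound 1 to compound 4 (0.01 log units; within the scatter) in this assay. Among the compounds shown here, this is the first direct test of this position, and on this evidence compound 1 and compound 4 cannot be told apart, so the added chloro brings no measurable gain here. No measurement at hand gives a reason for this result. This single step leaves open how a different group on the same carbon, such as an amine or a carboxylic acid, would compare. It also leaves open whether chloro would act the same way elsewhere on this ring.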